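From 2-fluorophenyl to 3-fluorophenyl: an unmeasured step

The source may hold more compounds than are shown below. What is called first, only, known or untested is meant among the compounds shown, and "the series" means these compounds.

Of the compounds shown here, three sharing one core have been read so far in a functional assay on HL-60 cells (Homo sapiens) for inhibition, read by MTT assay, with a stated time of 72 h; on this read-out lower numbers stand for stronger inhibition and higher numbers for weaker inhibition. Compound 1 `Cc1nc(-c2ccccc2)c(C(=O)N2CCN(c3ccc(C(F)(F)F)cc3)CC2)o1`, which carries 4-(trifluoromethyl)phenyl, gives only a limit, > 1000 nM. Compound 2 `Cc1nc(-c2ccccc2)c(C(=O)N2CCN(c3cccc(C(F)(F)F)c3)CC2)o1`, with 3-(trifluoromethyl)phenyl, gives 153 nM, and compound 3 `Cc1nc(-c2ccccc2)c(C(=O)N2CCN(c3ccccc3F)CC2)o1`, with 2-fluorophenyl, gives 147 nM. Compound 3 therefore stands level with compound 2, as a 1.0-fold lower number from compound 2 to compound 3 (0.02 log units; within the scatter) shows, and apart from compound 1, with an at least 6.8-fold lower number from compound 1 to compound 3 (0.83 log units; beyond the scatter).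

Compound 4 `Cc1nc(-c2ccccc2)c(C(=O)N2CCN(c3cccc(F)c3)CC2)o1` has 3-fluorophenyl in place of 2-fluorophenyl on an amine nitrogen in a ring, (3-fluorophenyl in place of 2-fluorophenyl on an amine nitrogen in a ring). The two compounds have the same atoms, joined differently. For the measured compounds named here, no measured step moves the fluorine itself, so the evidence is indirect. The large steps, an at least 6.5-fold lower number from compound 1 to compound 2 (0.81 log units; beyond the scatter) and an at least 6.8-fold lower number from compound 1 to compound 3 (0.83 log units; beyond the scatter), both start from compound 1 and its 4-(trifluoromethyl)phenyl group. Neither of them leads away from the level shared by compound 2 at 153 nM and compound 3 at 147 nM. A 3-substituted phenyl and a 2-substituted phenyl thus read alike here, and no step beyond the scatter is expected in this assay. The estimate means a 1.2-fold higher number from compound 3 to compound 4 (0.09 log units; within the scatter), with a slightly higher number expected. For compound 4 the estimated value is 180 nM, with an expected range from 70 nM to 500 nM.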

Compound 4, half-maximal inhibitory concentration: 45 nM
Estimate against measurement, compound 4: 4.0-fold (0.60 log units) above, and the stated range ends above it.
By their numbers in this assay, from the lowest: compound 4; then compounds 3 and 2 (each within the scatter of the next). At a limit, above all of these: compound 1.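

The earlier level between compound 2 and compound 3 had hidden the effect of where the fluorine sits, since those two compounds differ in both the group and its place on the phenyl ring. With fluorine as the only substituent, the shift from 2-fluorophenyl to 3-fluorophenyl alone gives a 3.3-fold lower number from compound 3 to compound 4 (0.51 log units; beyond the scatter) in this assay, so the place of the fluorine on this phenyl ring matters in its own right. With the place held, fluoro in place of trifluoromethyl on an aromatic carbon gives a 3.4-fold lower number from compound 2 to compound 4 (0.53 log units; beyond the scatter) in the same assay, and the widest step, an at least 22-fold lower number from compound 1 to compound 4 (1.34 log units; beyond the scatter), links 3-fluorophenyl with 4-(trifluoromethyl)phenyl, so compound 4 gives the lowest number of the series.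

These compounds leave open whether 4-fluorophenyl, 3-chlorophenyl or 3-methoxyphenyl would follow compound 4 or fall back to the level of compound 2 and compound 3. The value of compound 1 is a limit and not a number, so how far it lies from the others also stays open: the limit of > 1000 nM in this assay, at which 1 of the 4 values shown sits.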